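The source may report more compounds than this note shows. Statements on the series, on what has been measured and on what is new or still open speak of the compounds shown alone.

Measured in an ADME assay on Vero cells (Chlorocebus sabaeus) for cytotoxicity, read by MTT assay, with a stated time of 72 h; on this read-out lower numbers stand for higher toxicity in this test and higher numbers for lower toxicity in this test:
- Compound 1 `CCO/N=C1\C(=O)N(CCCOc2ccc3oc(-c4ccc(OC)cc4)c(C(=O)OCC)c3c2)c2ccccc21`: 16 ug/mL
- Compound 2 `CCOC(=O)c1c(-c2ccc(OC)cc2)oc2ccc(OCCCN3C(=O)/C(=N\OC)c4cc(OC)ccc43)cc12`: 128 ug/mL

Compound 2 has the higher number of the two, which means lower toxicity in this assay, and its gap to compound 1 lies beyond the usual scatter. Compound 3 `CCO/N=C1\C(=O)N(CCCOc2ccc3oc(-c4ccc(OC)cc4)c(C(=O)OCC)c3c2)c2ccc(OC)cc21` is not yet measured. It differs from compound 2 by methyl in place of hydrogen on a saturated chain carbon bound to an oxygen on an unsaturated carbon, so methoxy becomes ethoxy. Compound 1 also carries that ethoxy and gives 16 ug/mL, which points to a lower number. The expected change is a 2.8-fold lower number from compound 2 to compound 3 (0.45 log units; beyond the scatter). For compound 3 the estimated value is 45 ug/mL, with an expected range from 16 ug/mL to 128 ug/mL.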

Compound 3, half-maximal cytotoxic concentration: 32 ug/mL
Compound 3: the middle estimate sits 1.4-fold (0.15 log units) above what was measured; measured number inside the range.
By their numbers in this assay, from the lowest: compounds 1 and 3 (each within the scatter of the next); then compound 2.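

In this assay, among these compounds, the change from methoxy to ethoxy gives a 4.0-fold lower number from compound 2 to compound 3 (0.60 log units; beyond the scatter) and this is the first reading of that change with only one place differing. Methoxy in place of hydrogen on an aromatic carbon gives a 2.0-fold higher number from compound 1 to compound 3 (0.30 log units; within the scatter) and so shows no clear change, leaving the ethoxy change as the one step here that stands out. Nothing available here accounts for that step.
The compounds shown leave open how a longer chain such as propoxy, or an amine, would read at this place.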